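Benzyloxycarbonyl for Carbamoylmethyl: Expecting Compound 4

The source may report more compounds than this note shows. Statements on the series, on what has been measured and on what is new or still open speak of the compounds shown alone.

Compound 1: `NC(=O)CC[C@H](NC(=O)CN(c1ncnc2c1ncn2C1CCCCO1)C1CC1)C(=O)OCc1ccccc1` – 22.3%
Compound 2: `O=C(CN(c1nc(Cl)nc2[nH]cnc12)C1CC1)NCC(=O)OCc1ccccc1` – 21.7%
Compound 3: `C[C@@H](O)[C@H](NC(=O)CN(c1nc(Cl)nc2[nH]cnc12)C1CC1)C(=O)OCc1ccccc1` – 30.7%

In a functional assay on the whole organism (Tail, strain ICR) with Mus musculus as the target, in the tail flick test, with a stated time of 120 min, at a dose of 25 umol/kg by the oral route (a lower number here means a weaker effect, a higher number a stronger effect of the compound at the dose given), compound 1 gives 22.3%, the second highest of the three numbers. Nearest to it stands compound 2 with 21.7%, a gap within the scatter; furthest is compound 3 with 30.7%, also within the scatter. Among the measured compounds shown here, the one step between measured compounds that differ in one place, a number 9 percentage points higher from compound 2 to compound 3 (within the scatter), concerns a different group at a different place and is itself within the scatter.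

Compound 4 `O=C(CN(c1ncnc2c1ncn2C1CCCCO1)C1CC1)N[C@@H](CC(=O)OCc1ccccc1)C(=O)OCc1ccccc1` differs from compound 1 by benzyloxycarbonyl in place of carbamoylmethyl on a saturated chain carbon, two bonds along the chain from an amide-type nitrogen and a carbonyl carbon. For the measured compounds named here, no measured step touches this position or either of these groups, so the only guidance is that every measured change in this set has stayed within the scatter. Compound 4 is therefore expected to give a number close to that of compound 1, with a step of a number 0.7 percentage points higher from compound 1 to compound 4 (within the scatter) not beyond the scatter. The estimate for compound 4 is 23%, expected to lie between 12% and 36%.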

Compound 4, a percentage reported as activity, at one dose (the size of the read-out at that dose, not a potency): 7.82%
Compound 4: middle estimate off by 15.2 percentage points, on the high side; the measured number lies below the stated range.
By their numbers in this assay, from the lowest: compound 4; then compounds 2, 1 and 3 (each within the scatter of the next).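

Among the compounds shown here, this is the first step in the set that lies beyond the scatter: in this assay, benzyloxycarbonyl in place of carbamoylmethyl gives a number 14.5 percentage points lower from compound 1 to compound 4 (beyond the scatter), a modest step. For the compounds shown here, it shows that the group on this saturated chain carbon, two bonds along the chain from an amide-type nitrogen and a carbonyl carbon, can change the read-out, which the one earlier step, at a different place and within the scatter, could not show. Nothing measured here accounts for the lower number.

The change brings in a six-membered aromatic ring of carbon only and removes a hydrogen-bond donor together, so the compounds shown do not separate these two differences. Going by these compounds, how a carboxylic acid or an amine at this place would read also remains open.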